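An estimate for compound 4 from compound 2

The source may report more compounds than this note shows. Statements on the series, on what has been measured and on what is new or still open speak of the compounds shown alone.

Measured so far:
Compound 1 `Cc1ccc(-c2cc3ccccc3[nH]2)cc1`: 9.33%
Compound 2 `Brc1ccc(-c2cc3ccccc3[nH]2)cc1`: 4.8%
Compound 3 `COc1cc(OC)cc(-c2cc3ccccc3[nH]2)c1`: 9.18%

Three compounds sharing one core were tested in an assay on isolated protein for inhibition of Aromatase (Homo sapiens), read by fluorescence, using NADPH, with a stated time of 30 min, tested at 50 uM; on this read-out lower numbers stand for less inhibition and higher numbers for more inhibition at the one concentration tested (going by the name of the read-out). In this assay compound 1 gives 9.33%, compound 2 gives 4.8% and compound 3 gives 9.18%. Compound 2 has the lowest of the three numbers, but its gap to compound 3 and its gap to compound 1 both sit within the scatter, so no order among the three can be claimed; all three inhibit only weakly at the concentration tested.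

Within the data shown here, the one measured step that touches compound 2 is a number 4.5 percentage points lower from compound 1 to compound 2 (within the scatter), a change that stays within the scatter.

Compound 4 `Fc1ccc(-c2cc3ccccc3[nH]2)cc1` has not yet been measured. It differs from compound 2 by fluoro in place of bromo on an aromatic carbon. Among the measured compounds shown here, the only step that bears on this change is the one from compound 1 to compound 2, where one substituent on that same aromatic carbon was exchanged for another and the read-out hardly moved. The three measured numbers are also all close to one another regardless of substituent. The expectation is therefore a step of no size beyond the scatter, a number 2.2 percentage points higher from compound 2 to compound 4 (within the scatter), in this assay.

Compound 4 is accordingly expected to give about 7% in this assay, with a range from 0% to 16%.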

Compound 4, a percentage reported as inhibition, at one concentration (the size of the read-out at that concentration, not a potency): 21.8%
The estimate for compound 4 lay 14.8 percentage points below the measured number, outside the stated range (above it).
By their numbers in this assay, from the lowest: compounds 2, 3 and 1 (each within the scatter of the next); then compound 4.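

In this assay, the aromatic carbon para to a group of 9 heavy atoms proves sensitive to the choice of substituent, since fluoro in place of bromo gives a number 17 percentage points higher from compound 2 to compound 4 (beyond the scatter) and fluoro in place of methyl gives a number 12.5 percentage points higher from compound 1 to compound 4 (beyond the scatter). The earlier exchange of methyl for bromo had stayed within the scatter and hinted at a position indifferent to its substituent, whereas these two modest steps set compound 4 apart from both neighbours, even though bromo and fluoro are each a single heavy atom with no hydrogen-bond donors or acceptors. Nothing measured here accounts for why fluoro stands apart from bromo and methyl at this carbon.

The compounds shown leave open whether this rise belongs to fluoro alone or would also appear with chloro, an amine or a carboxylic acid on the same carbon. They also leave open whether fluoro would give a similar step on another carbon of that six-membered ring, and whether the rise would hold across a range of concentrations rather than at the single one tested.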